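Chloro in place of hydrogen on compound 2

The source may hold more compounds than are shown below. What is called first, only, known or untested is meant among the compounds shown, and "the series" means these compounds.

Measured in a functional assay on Bel-7402 cells (Homo sapiens) for inhibition, read by MTT assay, with a stated time of 24 h, tested at 0.1 ug/mL; a higher number here means more inhibition of growth at the concentration tested, a lower number less inhibition of growth:
Compound 1 `O=C(CCCCC(S)CCS)NO`: 5.96%
Compound 2 `O=C(CCCCC(S)CCS)Nc1ccccc1`: 0.85%
Not yet measured: compound 3 `O=C(CCCCC(S)CCS)Nc1ccc(Cl)cc1`

Going by the values given here, only two numbers are available so far, and they do not separate. Compound 2 stands at 0.85%, within the scatter of compound 1. Compound 3 differs from compound 2 by one change: chloro in place of hydrogen on an aromatic carbon. In words, this is chloro in place of hydrogen on an aromatic carbon, para to a large group.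

A single measured step bears on this, and only indirectly, since it concerns a phenyl in place of hydroxy on an amide-type nitrogen. That step is a number 5.1 percentage points lower from compound 1 to compound 2 (within the scatter). Among the compounds with values here, no measured pair shows what a chloro group does. With compound 2 at 0.85% and that one step inside the scatter, no step beyond the scatter is expected in this assay, and no direction can be favoured with any confidence.

The expected step is a number 2.2 percentage points higher from compound 2 to compound 3 (within the scatter). The estimate for compound 3 is 3%, with an expected range from 0% to 11%.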

Compound 3, percent growth inhibition at one concentration: 1.06%
Compound 3: middle estimate off by 1.9 percentage points, on the high side; measured number inside the range.
By their numbers in this assay, from the lowest: compounds 2, 3 and 1 (each within the scatter of the next).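

In this assay, going by these compounds alone, the step for chloro in place of hydrogen on an aromatic carbon, para to a large group, is a number 0.2 percentage points higher from compound 2 to compound 3 (within the scatter), and this is the first measured pair to bear on that position. At the single concentration tested, the chloro group therefore does not separate compound 3 from compound 2, which gives 0.85%, so this pair offers no sign that this change matters in this assay. No measurement is available to explain this result.

From the compounds shown here alone, whether an amine or a carboxylic acid at the same place on the aromatic ring, or a methoxy group there, would give a step beyond the scatter remains open, as does the effect of a longer chain in place of the one in the shared core. The values also leave open whether compound 2 and compound 3 would separate at any other concentration or exposure time, since a single tested condition cannot show how either compound behaves under another.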